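The source may report more compounds than this note shows. Statements on the series, on what has been measured and on what is new or still open speak of the compounds shown alone.

Compound 1 `CC(C)Oc1cc(-c2cncc(-c3cnn(C(C)C)c3)c2)ccc1C(N)=O`: 940 nM
Compound 2 `Cc1n[nH]c(C)c1-c1cncc(-c2ccc(C(N)=O)c(OC(C)C)c2)c1`: 160 nM
Compound 3 `CC(C)Oc1cc(-c2cncc(-c3cnn(C4CCOC4)c3)c2)ccc1C(N)=O`: 390 nM

These three compounds share one core and were measured in an assay on HeLa cells for inhibition of MAP kinase-interacting serine/threonine-protein kinase 1/2 (Homo sapiens), read by AlphaScreen, with a stated time of 2 h; on this read-out lower numbers stand for stronger inhibition and higher numbers for weaker inhibition. Compound 2 gives the lowest number of the three. Compound 3 comes nearest to it, and compound 1 lies furthest away; the step of a 5.9-fold lower number from compound 1 to compound 2 (0.77 log units; beyond the scatter) and the step of a 2.4-fold lower number from compound 1 to compound 3 (0.38 log units; beyond the scatter) are both beyond the scatter.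

Compound 4 `CNC(=O)c1cncc(-c2ccc(C(N)=O)c(OC(C)C)c2)c1` has not yet been measured. It differs from compound 2 in one place: methylcarbamoyl in place of 3,5-dimethyl-1H-pyrazol-4-yl on an aromatic carbon. Both measured steps concern the group at this same position, yet each keeps the five-membered ring and alters only what is attached to it, and those changes alone shifted the read-out by a 5.9-fold lower number from compound 1 to compound 2 (0.77 log units; beyond the scatter) and by a 2.4-fold lower number from compound 1 to compound 3 (0.38 log units; beyond the scatter). Going by the values given here, no measured step removes the ring itself, so the present change goes further than anything observed. Since compound 2 holds the lowest number and the group at this position has been the deciding one, a higher number is expected for compound 4 in this assay, beyond the scatter, though its size is uncertain. Compound 4 is therefore estimated at 1200 nM, between 350 nM and 4500 nM. This estimate corresponds to an expected step of a 7.5-fold higher number from compound 2 to compound 4 (0.88 log units; beyond the scatter).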

Compound 4, half-maximal inhibitory concentration: 1900 nM
For compound 4 the middle estimate is 1.6-fold (0.20 log units) below the measured one; low and high end bracket the measured number.
By their numbers in this assay, from the lowest: compound 2; then compound 3; then compound 1; then compound 4.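

In this assay, methylcarbamoyl in place of 3,5-dimethyl-1H-pyrazol-4-yl gives a 12-fold higher number from compound 2 to compound 4 (1.07 log units; beyond the scatter), a large step and the first at this position to remove the five-membered ring rather than alter what is attached to it. The same group in place of 1-isopropyl-1H-pyrazol-4-yl gives a 2.0-fold higher number from compound 1 to compound 4 (0.31 log units; beyond the scatter), and the step from compound 2 occurs although the leaving and entering groups have equal counts of hydrogen-bond donors and acceptors. Nothing in the data explains why the number rises with this change.

The compounds shown leave open whether the ring itself matters or only the size of the group on this aromatic carbon. A longer chain such as ethylcarbamoyl, or a six-membered ring such as phenyl, at the same position could help separate the two.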